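The source may hold more compounds than are shown below. What is called first, only, known or untested is meant among the compounds shown, and "the series" means these compounds.

Going by the values given here, in a functional assay on U-937/GTB cells (Homo sapiens) for cytotoxicity (on this read-out lower numbers stand for stronger inhibition and higher numbers for weaker inhibition), compound 1 (`CO/N=c1\[nH]cnc2c1[n+](C/C=C(\C)CC/C=C(\C)CCC=C(C)C)cn2C`) gives 1320 nM and compound 2 (`CO/N=c1\[nH]cnc2c1[n+](C/C=C(\C)CC/C=C(/C)CCC=C(C)C)cn2C`) gives 1400 nM, so compound 2 stands level with the only other measured compound. Compound 3 (`CC(C)=CCC/C(C)=C\CC/C(C)=C/C[n+]1cn(C)c2nc[nH]/c(=N\OCc3ccccc3)c21`) differs from compound 2 as follows: phenyl in place of hydrogen on a saturated chain carbon bound to an oxygen; methoxy becomes benzyloxy. Among the compounds with values here, the sole measured step, a 1.1-fold higher number from compound 1 to compound 2 (0.03 log units; within the scatter), reflects the fact that compounds 1 and 2 differ only in the configuration as drawn and leaves this group untouched, so it offers no measure of the change. Starting from compound 2 at 1400 nM, no shift beyond the scatter is expected in this assay, and the estimated step is a 1.1-fold lower number from compound 2 to compound 3 (0.03 log units; within the scatter). For compound 3 the expected value is 1300 nM, within a wide range of 500 nM to 3200 nM.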

Compound 3, half-maximal inhibitory concentration: 7550 nM
For compound 3 the middle estimate is 5.8-fold (0.76 log units) below the measured one; the measured number lies above the stated range.
By their numbers in this assay, from the lowest: compounds 1 and 2 (each within the scatter of the next); then compound 3.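

In this assay the change from methoxy to benzyloxy gives a 5.4-fold higher number from compound 2 to compound 3 (0.73 log units; beyond the scatter), so the group on this oxygen matters to inhibition, and the added phenyl weakens it. The earlier pair could not show this, as its only difference was the configuration of one double bond, and its step lay within the scatter. Nothing in the data given accounts for this loss. The compounds shown leave open how an ethoxy group or a hydroxy group would fare here, and so whether the loss follows the phenyl ring itself or the longer chain.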